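Sulfonyl aryl variation on the shared core: compound 3 to 4

The source may hold more compounds than are shown below. What is called first, only, known or untested is meant among the compounds shown, and "the series" means these compounds.

The series shares the core of compound 1 `CC1=NC(c2cn(S(=O)(=O)c3ccc(C)cc3)c3ccccc23)CN1` and varies the aryl group on the sulfonyl sulfur. In an assay on isolated protein for inhibition of kallikrein-7 (Homo sapiens), read by fluorescence, with stated times of 10 min and 30 min (a lower number here means a stronger inhibitor, a higher number a weaker inhibitor), compound 1 gives 10000 nM. Compound 2 `CC1=NC(c2cn(S(=O)(=O)c3cccc(Cl)c3)c3ccccc23)CN1` carries 3-chlorophenyl in place of 4-methylphenyl; in this assay compound 2 reports only a limit, > 30000 nM, and so sits at the limit of > 30000 nM in this assay, at which 1 of the 3 values shown sits. Within the data shown here, the step of an at least 3.0-fold higher number from compound 1 to compound 2 (0.47 log units; beyond the scatter) is the one measured change on the sulfonyl sulfur. Compound 3 `CC1=NC(c2cn(S(=O)(=O)c3cccc(Cl)c3)c3ccc(C)cc23)CN1` adds methyl on an aromatic carbon of the core; in this assay compound 3 gives 30000 nM, the highest of the two numbers shown, with a number no higher from compound 2 to compound 3 (the limit leaves the size open).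

Compound 4 `CC1=NC(c2cn(S(=O)(=O)c3ccccc3Br)c3ccc(C)cc23)CN1` differs from compound 3 by 2-bromophenyl in place of 3-chlorophenyl on a sulfonyl sulfur. Among the measured compounds shown here, only the step from compound 1 to compound 2 bears on a change of the aryl group here, and it read as a weakening; the step from compound 2 to compound 3 gives no readable size. For compound 4 the step of no change at the digits printed from compound 3 to compound 4 (within the scatter) is expected to stay within the scatter, with a high chance of a limit. The estimate for compound 4 in this assay is 30000 nM, expected between 10000 nM and 100000 nM.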

Compound 4, half-maximal inhibitory concentration: 390 nM
Beside the measured number, compound 4's estimate is 77-fold (1.89 log units) above it, outside the stated range (below it).
By their numbers in this assay, from the lowest: compound 4; then compound 1; then compound 3.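

The sulfonyl aryl group is not limited to weakening changes. In this assay, among these compounds, 2-bromophenyl in place of 3-chlorophenyl gives a 77-fold lower number from compound 3 to compound 4 (1.89 log units; beyond the scatter), whereas the only earlier change on the sulfonyl sulfur gave an at least 3.0-fold higher number from compound 1 to compound 2 (0.47 log units; beyond the scatter), so the direction of the step depends on which aryl group enters. The two groups exchanged in the new step match in heavy-atom count and in their zero counts of hydrogen-bond donors and acceptors, so those counts do not separate them, and nothing measured here gives a reason for the step.

This step changes the halogen and its place on the phenyl ring together, so the share of each cannot be read. From the compounds shown here alone, how 2-chlorophenyl, 3-bromophenyl or a phenyl carrying an amine or a carboxylic acid would read on the sulfonyl sulfur remains open.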